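The compounds below may be only part of what the source reports. "The series", "measured", "known", "first", "only" and "open" are said of these compounds alone.

Compound 1 `CCN(CC)CCCCn1c(N)c(-c2nc3ccccc3[nH]2)c2nc(C#N)c(C#N)nc21` gives 10100 nM in a functional assay on HeLa cells (Homo sapiens) for antiproliferative activity, read by MTT assay, with a stated time of 48 h; a higher number here means a weaker inhibitor, a lower number a stronger inhibitor.
Compound 2 `CN(C)CCCCCn1c(N)c(-c2nc3ccccc3[nH]2)c2nc(C#N)c(C#N)nc21` gives 10800 nM in this assay.
Compound 3 `CCN(CC)CCn1c(N)c(-c2nc3cc(Cl)ccc3[nH]2)c2nc(C#N)c(C#N)nc21` gives > 50000 nM in this assay, which is a limit of the assay and not a number.

Compound 1 and compound 2 share one core and differ only at the end of the chain on the aromatic nitrogen: (dimethylamino)methyl in place of diethylamino on a saturated chain carbon, four bonds along the chain from an aromatic nitrogen. The result is a 1.1-fold higher number from compound 1 to compound 2 (0.03 log units; within the scatter), so the two compounds cannot be told apart. Compound 3 sits at the limit of > 50000 nM in this assay, at which 1 of the 3 values shown sits, so only a limit is known for it. How the core of compound 3 differs from that of compound 1 is not broken down here.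

Compound 4 `CN(C)CCCn1c(N)c(-c2nc3cc(Cl)ccc3[nH]2)c2nc(C#N)c(C#N)nc21` has not been measured. It stands to compound 3 as compound 2 stands to compound 1: (dimethylamino)methyl in place of diethylamino on a saturated chain carbon, two bonds along the chain from an aromatic nitrogen. The place is not the same word for word, two bonds along the chain from an aromatic nitrogen rather than four, so this is the same kind of change, not the same one. The step is expected to be small, a step that the limit leaves unreadable from compound 3 to compound 4, resting on a 1.1-fold higher number from compound 1 to compound 2 (0.03 log units; within the scatter). Compound 4 is therefore expected to give 60000 nM in this assay, most likely again as a limit, with a range from 20000 nM to 200000 nM.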

Compound 4, half-maximal inhibitory concentration: 16500 nM
Beside the measured number, compound 4's estimate is 3.6-fold (0.56 log units) above it; the measured number lies below the stated range.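

On the core of compound 3, the change in this assay gives an at least 3.0-fold lower number from compound 3 to compound 4 (0.48 log units; beyond the scatter), so a step that was too small to read on one core cannot be assumed to stay that small on another, although these compounds do not show which difference between the two cores is responsible. Set side by side, the two steps do not agree: the same change on two cores in this assay, a 1.1-fold higher number (0.03 log units; within the scatter) from compound 1 to compound 2 and an at least 3.0-fold lower number (0.48 log units; beyond the scatter) from compound 3 to compound 4, at least 3.2-fold (0.51 log units) apart, beyond the scatter of two such steps. Only a minimum is known for the size of the second step, for the entry for compound 3 is a limit of the assay and not a number: the limit of > 50000 nM in this assay, at which 1 of the 4 values shown sits.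

The compounds shown leave open whether a ring amine such as piperidine or morpholine at the end of the chain would follow the diethylamino or the dimethylamino result on either core. They also leave open how a longer chain would read on the chlorine-bearing core, and whether a fluorine in place of that chlorine would bring the two steps closer together.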